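The source may hold more compounds than are shown below. What is called first, only, known or untested is meant among the compounds shown, and "the series" means these compounds.

Three hydrazones sharing one core have been measured in an assay on isolated protein for inhibition of Amine oxidase [flavin-containing] A (Homo sapiens), read by fluorescence, with a stated time of 20 min; a lower number here means a stronger inhibitor, a higher number a weaker inhibitor. Compound 1 `CC(C)=NNc1nc(-c2cccc([N+](=O)[O-])c2)cs1` gives 1070 nM. Compound 2 `CCC/C(C)=N\Nc1nc(-c2cccc([N+](=O)[O-])c2)cs1` gives 38000 nM, the highest of the three numbers. Compound 3 `C/C(CC(C)C)=N/Nc1nc(-c2cccc([N+](=O)[O-])c2)cs1` gives 4410 nM. Compound 2 thus stands furthest from compound 1, as a 36-fold higher number from compound 1 to compound 2 (1.55 log units; beyond the scatter) shows, and nearest to compound 3, as an 8.6-fold lower number from compound 2 to compound 3 (0.94 log units; beyond the scatter) shows. The unmeasured compound 4 `CCC/C(CC)=N\Nc1nc(-c2cccc([N+](=O)[O-])c2)cs1` differs from compound 2 by methyl in place of hydrogen on a saturated chain carbon bound to a carbon with a double bond to nitrogen. One earlier step also added carbon at this same place, a 4.1-fold higher number from compound 1 to compound 3 (0.62 log units; beyond the scatter), and, together with the step from compound 1 to compound 2 already named, it points toward a weaker inhibitor when this position grows. The step adding carbon elsewhere on the chain went the other way. The measured steps all exceed the scatter but disagree in direction. Only a modest move is expected for compound 4, most likely toward a higher number, as a 1.2-fold higher number from compound 2 to compound 4 (0.07 log units; within the scatter). Compound 4 is therefore estimated in this assay at 45000 nM, with a range from 12000 nM to 150000 nM.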

Compound 4, half-maximal inhibitory concentration: 4860 nM
For compound 4 the middle estimate is 9.3-fold (0.97 log units) above the measured one, outside the stated range (below it).
By their numbers in this assay, from the lowest: compound 1; then compounds 3 and 4 (each within the scatter of the next); then compound 2.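

In this assay, methyl in place of hydrogen on a saturated chain carbon bound to a carbon with a double bond to nitrogen gives a stronger inhibitor here (a 7.8-fold lower number from compound 2 to compound 4 (0.89 log units; beyond the scatter)), so added carbon at this place does not always weaken inhibition. Even so, compound 4 remains a weaker inhibitor than the smallest member of the set (a 4.5-fold higher number from compound 1 to compound 4 (0.66 log units; beyond the scatter)), and its number cannot be told apart from that of its isomeric neighbour (a 1.1-fold higher number from compound 3 to compound 4 (0.04 log units; within the scatter)), which leaves compound 2 alone at the high end. Nothing available accounts for this reversal.

Going by these compounds, whether the trend continues with a longer chain at this place, or holds with a hydroxyl or an amine there, remains open. On these data alone, whether the same step would repeat on a different core is also open.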